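The compounds below may be only part of what the source reports. "The series", "measured", "known", "first", "only" and "open" are said of these compounds alone.

Measured compounds:
- compound 1, `O=C(Nc1ccc(Cl)cc1)NS(=O)(=O)c1cccs1`: 16%
- compound 2, `CCCc1ccc(S(=O)(=O)NC(=O)Nc2ccc(Cl)cc2)s1`: 38%
- compound 3, `CCCOc1ccc(S(=O)(=O)NC(=O)Nc2ccc(Cl)cc2)s1`: 44%

In a functional assay on the whole organism (6C3HED cells, Mus musculus) for inhibition, at a dose of 150 mg/kg by the oral route (on this read-out higher numbers stand for more inhibition at the one dose given (going by the name of the read-out) and lower numbers for less inhibition), compound 1 gives the lowest of the three numbers: compound 2 stands higher by a number 22 percentage points higher from compound 1 to compound 2 (beyond the scatter), and compound 3 stands higher still by a number 28 percentage points higher from compound 1 to compound 3 (beyond the scatter). Compound 2 and compound 3 are separated only by a number 6 percentage points higher from compound 2 to compound 3 (within the scatter), which lies within the scatter.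

Compound 4, `CCc1ccsc1S(=O)(=O)NC(=O)Nc1ccc(Cl)cc1`, has not yet been measured in this assay. Compared with compound 1 it carries the change (ethyl in place of hydrogen on an aromatic carbon).

Going by the values given here, two measured steps bear on this: the propyl in place of hydrogen that takes compound 1 to compound 2, and the propoxy in place of hydrogen that takes compound 1 to compound 3. Both were modest rises beyond the scatter. The change to compound 4 likewise puts a small carbon chain onto the five-membered ring of the shared core, though the chain is ethyl and the place is a different aromatic carbon, two ring bonds from the ring sulfur. Among the compounds with values here, on that account a modest rise is expected rather than none, but a smaller one than the measured steps, since no compound on record tests this exact place or chain. The estimated step for compound 4 is a number 12 percentage points higher from compound 1 to compound 4 (beyond the scatter), giving an expected value of 28%, with a likely range from 14% to 44%.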

Compound 4, a percentage reported as inhibition, in the whole organism at one dose (the size of the read-out at that dose, not a potency): 21%
For compound 4 the middle estimate is 7 percentage points above the measured one, and the stated range covers the measured number.
By their numbers in this assay, from the lowest: compounds 1 and 4 (each within the scatter of the next); then compounds 2 and 3 (each within the scatter of the next).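

In this assay, ethyl in place of hydrogen on this aromatic carbon, two ring bonds from the ring sulfur, gives a number 5 percentage points higher from compound 1 to compound 4 (within the scatter) and so cannot be told apart from compound 1 on this read-out. The earlier compounds shown here showed only that propyl and propoxy on a different aromatic carbon of the same ring go with a number 22 percentage points higher from compound 1 to compound 2 (beyond the scatter) and a number 28 percentage points higher from compound 1 to compound 3 (beyond the scatter), while compound 4 shows that a small carbon chain on this ring does not bring a rise beyond the scatter wherever it stands, although chain and place both differ here, so neither can be singled out as what matters. Nothing available offers an explanation for this result.

The compounds shown leave open whether propyl or propoxy at this same carbon would behave as ethyl does here, and whether ethyl at the carbon that carries propyl in compound 2 would keep that rise. They also leave open how a methyl group, a longer chain such as butyl, an amine or a carboxylic acid would read at this place on the shared core.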